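From (pyridin-2-yl)oxy to methylsulfanyl on the shared core

The source may report more compounds than this note shows. Statements on the series, on what has been measured and on what is new or still open speak of the compounds shown alone.

In a functional assay on HL-60 cells (Homo sapiens) for inhibition, read by XTT assay, with a stated time of 72 h (on this read-out higher numbers stand for weaker inhibition and lower numbers for stronger inhibition), compound 1 (`[N-]=[N+]=NCc1ncnc2c1ncn2[C@@H]1O[C@H](CO)[C@@H](O)[C@H]1O`), with azido, gives 780 nM as its number. Compound 2 (`OC[C@H]1O[C@@H](n2cnc3c(Cn4ccc5ccccc54)ncnc32)[C@H](O)[C@@H]1O`) gives 9100 nM and compound 3 (`OC[C@H]1O[C@@H](n2cnc3c(COc4ccccn4)ncnc32)[C@H](O)[C@@H]1O`) gives 14300 nM on the same read-out. Compound 3 thus stays level with compound 2 (a 1.6-fold higher number from compound 2 to compound 3 (0.20 log units; within the scatter)) and lies well clear of compound 1 (an 18-fold higher number from compound 1 to compound 3 (1.26 log units; beyond the scatter)). Compound 4 (`CSCc1ncnc2c1ncn2[C@@H]1O[C@H](CO)[C@@H](O)[C@H]1O`) has methylsulfanyl in place of (pyridin-2-yl)oxy on a saturated chain carbon bound to an aromatic carbon. 1H-indol-1-yl likewise stands far from azido (a 12-fold higher number from compound 1 to compound 2 (1.07 log units; beyond the scatter)). Methylsulfanyl has no ring, and neither has azido, so a clearly lower number is expected, although no measured step involves methylsulfanyl. The expected change is a sizeable one (a 7.2-fold lower number from compound 3 to compound 4 (0.85 log units; beyond the scatter)). The estimate for compound 4 is 2000 nM (expected range 300 nM to 12000 nM).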

Compound 4, half-maximal inhibitory concentration: 5000 nM
Estimate against measurement, compound 4: 2.5-fold (0.40 log units) below; the measured number falls inside the stated range.
By their numbers in this assay, from the lowest: compound 1; then compounds 4, 2 and 3 (each within the scatter of the next, the first and the last beyond it).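

In this assay, removing the ring recovers only part of the distance to azido: the change gives (a 2.9-fold lower number from compound 3 to compound 4 (0.46 log units; beyond the scatter)), yet methylsulfanyl remains short of azido (a 6.4-fold higher number from compound 1 to compound 4 (0.81 log units; beyond the scatter)). Against 1H-indol-1-yl, methylsulfanyl shows no clear separation (a 1.8-fold lower number from compound 2 to compound 4 (0.26 log units; within the scatter)), so having no ring does not alone bring a compound level with compound 1. Nothing measured here accounts for the gap between the two ringless groups.

On these data alone, whether a primary amine on a saturated chain carbon bound to an aromatic carbon would come closer to azido remains open. So does whether methoxy would match methylsulfanyl.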